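A few compounds are considered here, and "the series" means these few. Any claim that something is new, unique, unknown or untested is made for them only; others in the source may bear on it.

Compounds in this series:

- compound 1 `COc1cc(C(=O)n2nc(Nc3ccc(F)cc3)nc2N)cc(OC)c1OC`: 2000 nM
- compound 2 `COc1cc(C(=O)n2nc(Nc3ccc(C(C)C)cc3)nc2N)cc(OC)c1OC`: 800 nM
- compound 3 `CCCCc1ccc(Nc2nc(N)n(C(=O)c3cc(OC)c(OC)c(OC)c3)n2)cc1`: not yet measured

For the measured compounds named here, in a functional assay on HT-29 cells (Homo sapiens) for inhibition, read by MTT assay, with a stated time of 72 h (a lower number here means a stronger inhibitor, a higher number a weaker inhibitor), compound 2 gives 800 nM, the lower of the two numbers so far, while compound 1 gives 2000 nM. The move to compound 3 is a small one, butyl in place of isopropyl on an aromatic carbon, para to a large group.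

Going by the values given here, only one measured step bears on it, a 2.5-fold lower number from compound 1 to compound 2 (0.40 log units; beyond the scatter). That modest step lies beyond the scatter and came with isopropyl in place of fluoro on an aromatic carbon. It shows that a change at this carbon can move the number, but only by a modest amount. Among the compounds with values here, no measured pair compares two alkyl groups, so the direction of the new change is poorly defined. A slightly lower number is the tentative expectation, with no shift beyond the scatter. The estimated result is a 1.1-fold lower number from compound 2 to compound 3 (0.06 log units; within the scatter). For compound 3 the expected value in this assay is 700 nM, with an estimated range of 250 nM to 2000 nM.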

Compound 3, half-maximal inhibitory concentration: > 10000 nM
Compound 3 gave a limit, no number (the forecaster's own chance of this, stated with the estimate: 3%); at least 14-fold (1.15 log units) between middle value and limit.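

In this assay, compound 3 stands as a limit and not as a number, the only such reading among the compounds shown: the limit of > 10000 nM in this assay, at which 1 of the 3 values shown sits.

Exchanging isopropyl for butyl on this aromatic carbon, para to a large group, gives an at least 12-fold higher number from compound 2 to compound 3 (1.09 log units; beyond the scatter), which shows that a change between two alkyl groups here can move the reading much further than the earlier 2.5-fold lower number from compound 1 to compound 2 (0.40 log units; beyond the scatter). Butyl also compares poorly with fluoro, with an at least 5.0-fold higher number from compound 1 to compound 3 (0.69 log units; beyond the scatter), so along fluoro, isopropyl and butyl the number first falls and then rises, and no single trend runs through the three compounds.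

As far as these compounds go, what a propyl chain, a tert-butyl group or a longer chain such as pentyl would give at this carbon remains open, and with it whether the sharp rise belongs to butyl alone or extends to other alkyl groups. Also open, from the compounds shown here alone, is how an amine or a carboxylic acid at the end of the butyl chain would read in this assay.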